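A few compounds are considered here, and "the series" means these few. Any claim that something is new, unique, unknown or untested is made for them only; others in the source may bear on it.

Measured compounds:
- compound 1, `Cc1cc(C)cc(Cc2ccc3c(NCCCNCc4ccco4)ccnc3c2)c1`: 6270 nM
- compound 2, `c1coc(CNCCCNc2ccnc3cc(CC4CCCCC4)ccc23)c1`: 1700 nM
- compound 3, `COc1ccc(F)cc1CNCCCNc1ccnc2cc(Cc3cc(C)cc(C)c3)ccc12`: 940 nM

All three values come from an ADME assay on HepG2 cells (Homo sapiens) for cytotoxicity, read by luminescence, CellTiter-Glo and ATP content, with a stated time of 72 h; on this read-out lower numbers stand for an effect already at smaller amounts and higher numbers for an effect only at larger amounts of compound. Compound 1 gives 6270 nM in this assay, compound 2 gives 1700 nM, and compound 3 gives 940 nM. The change cyclohexyl in place of 3,5-dimethylphenyl on a saturated chain carbon bound to an aromatic carbon gives a 3.7-fold lower number from compound 1 to compound 2 (0.57 log units; beyond the scatter). The change 5-fluoro-2-methoxyphenyl in place of furan-2-yl on a saturated chain carbon bound to an amine nitrogen gives a 6.7-fold lower number from compound 1 to compound 3 (0.82 log units; beyond the scatter). Compound 3 carries the lowest number of the three, but its gap to compound 2 lies within the scatter, so no order between compound 2 and compound 3 is claimed.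

Compound 4, `COc1ccc(F)cc1CNCCCNc1ccnc2cc(CC3CCCCC3)ccc12`, has not been measured in this assay. It differs from compound 3 by cyclohexyl in place of 3,5-dimethylphenyl on a saturated chain carbon bound to an aromatic carbon. Within the data shown here, this is the same change as the one from compound 1 to compound 2, made at the same place; the two cores differ by 5-fluoro-2-methoxyphenyl in place of furan-2-yl on a saturated chain carbon bound to an amine nitrogen. Among the measured compounds shown here, the change has been seen once so far, and its size there is the only guide.

For compound 4 a step of about a 2.7-fold lower number from compound 3 to compound 4 (0.43 log units; beyond the scatter) in this assay is expected, somewhat smaller than a 3.7-fold lower number from compound 1 to compound 2 (0.57 log units; beyond the scatter), because compound 3 already stands at 940 nM and the second change on the same core has not been measured, so a partial carry-over is assumed rather than a full one. On this basis compound 4 is estimated at 350 nM in this assay, with a range from 150 nM to 900 nM expected to cover most repeats.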

Compound 4, half-maximal effective concentration: 1830 nM
For compound 4 the middle estimate is 5.2-fold (0.72 log units) below the measured one; the measured number lies above the stated range.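

In this assay, the change from 3,5-dimethylphenyl to cyclohexyl did not carry over from one core to the other, so the earlier step is a poor guide to its size on a new core: the same change on two cores in this assay, a 3.7-fold lower number (0.57 log units; beyond the scatter) from compound 1 to compound 2 and a 1.9-fold higher number (0.29 log units; within the scatter) from compound 3 to compound 4, 7.2-fold (0.86 log units) apart, beyond the scatter of two such steps. The same four compounds can be read the other way round, and the change from furan-2-yl to 5-fluoro-2-methoxyphenyl also depends on the group at the other end of the molecule: the same change on two cores in this assay, a 6.7-fold lower number (0.82 log units; beyond the scatter) from compound 1 to compound 3 and a 1.1-fold higher number (0.03 log units; within the scatter) from compound 2 to compound 4, 7.2-fold (0.86 log units) apart, beyond the scatter of two such steps. With cyclohexyl and 5-fluoro-2-methoxyphenyl together, the two new steps are a 1.9-fold higher number from compound 3 to compound 4 (0.29 log units; within the scatter) and a 1.1-fold higher number from compound 2 to compound 4 (0.03 log units; within the scatter), so the two changes do not add up in this set, although one set of four compounds does not show why, nor whether this holds for other groups in these two places.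

The compounds shown leave open whether cyclopentyl or unsubstituted phenyl, on the saturated chain carbon bound to an aromatic carbon, would follow the core of compound 1 or that of compound 3. From the compounds shown here alone, it also remains open whether pyridin-3-yl or unsubstituted phenyl, on the saturated chain carbon bound to an amine nitrogen, would restore a step of the earlier size.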